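Amide-Linked Diol Replaces Dihydroxyethyl on the Piperidine Chain

This account rests on a few compounds, and the source may have more. Where it says the series, first, only, none or still open, it means among the compounds named here.

Among the compounds with values here, compound 1 `Cn1ncc(Cl)c1-c1cc(C(=O)N[C@@H]2CN[C@H](CC(O)CO)C[C@H]2c2ccc(Cl)c(Cl)c2)oc1Cl` is tested in a functional assay on OVCAR-8 cells (Homo sapiens) for antiproliferative activity (a lower number here means a stronger inhibitor, a higher number a weaker inhibitor), where compound 1 gives 1610 nM, the highest of the three numbers known here. Its two comparators are compound 2 `Cn1ncc(Cl)c1-c1cc(C(=O)N[C@@H]2CN[C@H](CCCO)C[C@H]2c2ccc(Cl)c(Cl)c2)oc1Cl`, which gives 600 nM, and compound 3 `Cn1ncc(Cl)c1-c1cc(C(=O)N[C@@H]2CN[C@H](CCn3cncn3)C[C@H]2c2ccc(Cl)c(Cl)c2)oc1Cl`, which gives 1560 nM. The change to compound 4 `Cn1ncc(Cl)c1-c1cc(C(=O)N[C@@H]2CN[C@H](CC(=O)NCC(O)CO)C[C@H]2c2ccc(Cl)c(Cl)c2)oc1Cl` is (2,3-dihydroxypropyl)carbamoyl in place of 1,2-dihydroxyethyl on a saturated chain carbon bound to a saturated ring carbon. Within the data shown here, two measured steps bear on this. Removing a hydroxy from the chain gave a 2.7-fold lower number from compound 1 to compound 2 (0.43 log units; beyond the scatter), while swapping the 1,2-dihydroxyethyl for (1H-1,2,4-triazol-1-yl)methyl gave a 1.0-fold lower number from compound 1 to compound 3 (0.01 log units; within the scatter); between those two, a 2.6-fold higher number from compound 2 to compound 3 (0.41 log units; beyond the scatter) was seen. None of these introduces an amide or lengthens the chain, so the new group stands outside what the measured steps cover. With the diol retained but moved further out through a carbamoyl linker, no step beyond the scatter is expected in this assay, leaning if anything to a slightly higher number. Compound 4 is therefore estimated at 1900 nM, within 700 nM to 5000 nM, which would mean an expected step of a 1.2-fold higher number from compound 1 to compound 4 (0.07 log units; within the scatter).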

Compound 4, half-maximal inhibitory concentration: 5900 nM
Estimate against measurement, compound 4: 3.1-fold (0.49 log units) below, and the stated range ends below it.
By their numbers in this assay, from the lowest: compound 2; then compounds 3 and 1 (each within the scatter of the next); then compound 4.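

At this place, on a saturated chain carbon bound to a saturated ring carbon, the (2,3-dihydroxypropyl)carbamoyl group raises the number in this assay against all three earlier compounds (a 3.7-fold higher number from compound 1 to compound 4 (0.56 log units; beyond the scatter); a 3.8-fold higher number from compound 3 to compound 4 (0.58 log units; beyond the scatter); a 9.8-fold higher number from compound 2 to compound 4 (0.99 log units; beyond the scatter)). Within the data shown here, compound 4 is therefore the weakest of the four, and the position proves less tolerant than the earlier compounds suggested. Carrying a diol further out on a carbamoyl link does not preserve the activity of compound 1, which holds its diol closer in. Nothing measured here explains the rise.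

Compound 4 changes the link and the length together, so the shown compounds cannot separate the contribution of the amide from that of the longer chain. On these data alone, a simple methylcarbamoyl group, or a longer diol chain without the carbonyl, remains open at this place.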